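Swapping the Chloropyridine Tail for a Nitrophenyl Group

A few compounds are considered here, and "the series" means these few. Any claim that something is new, unique, unknown or untested is made for them only; others in the source may bear on it.

Measured so far, in a functional assay on HeLa cells (Homo sapiens) for inhibition, with a stated time of 72 h; a higher number here means that more compound is needed for the effect, a lower number that less compound is needed:
Compound 1, `COc1cc(CNCc2ccncc2)ccc1OCc1cccc(F)c1`: compound 1 gives 4800 nM.
Compound 2, `COc1cc(CNCc2ccncc2)ccc1OCc1ccc(F)cc1`: compound 2 gives 6400 nM.
Compound 3, `COc1cc(CNCc2ccncc2)ccc1OCc1ccc(Cl)nc1`: compound 3 gives 400 nM.

Compound 3 stands at the lowest number of the three, meaning the least compound is needed for the effect. The two fluorophenyl compounds sit close together, with a 1.3-fold higher number from compound 1 to compound 2 (0.12 log units; within the scatter), a gap within the scatter. Replacing either fluorophenyl by the chloropyridine gives a large gain: a 12-fold lower number from compound 1 to compound 3 (1.08 log units; beyond the scatter) and a 16-fold lower number from compound 2 to compound 3 (1.20 log units; beyond the scatter).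

Compound 4, `COc1cc(CNCc2ccncc2)ccc1OCc1ccc([N+](=O)[O-])cc1`, differs from compound 3 in one place: 4-nitrophenyl in place of 6-chloropyridin-3-yl on a saturated chain carbon bound to an oxygen on an aromatic ring. Going by the values given here, no measured step involves a nitrophenyl group, so the measured steps bear on it only indirectly. They show that a carbon-only ring carrying fluorine sits far behind the chloropyridine, and compound 4 returns to a carbon-only ring, though with a nitro group that the fluorophenyl compounds lack. A rise in the number from compound 3 is therefore expected, though probably not all the way back to where compound 1 and compound 2 lie; the expected step is a 6.3-fold higher number from compound 3 to compound 4 (0.80 log units; beyond the scatter). In this assay compound 4 is estimated at 2500 nM, with a likely range from 600 nM to 8000 nM.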

Compound 4, half-maximal effective concentration: 440 nM
Estimate against measurement, compound 4: 5.7-fold (0.75 log units) above; the whole stated range lies above it.
By their numbers in this assay, from the lowest: compounds 3 and 4 (each within the scatter of the next); then compounds 1 and 2 (each within the scatter of the next).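

In this assay, putting 4-nitrophenyl in place of 6-chloropyridin-3-yl gives a 1.1-fold higher number from compound 3 to compound 4 (0.04 log units; within the scatter), so at this position the ring nitrogen and the chlorine can both leave without a change that stands out from the scatter. The earlier compounds shown here left open whether a ring of carbon only would always sit at the high numbers of the fluorophenyl compounds, and compound 4 shows that it need not: nitro in place of fluoro on an aromatic carbon gives a 15-fold lower number from compound 2 to compound 4 (1.16 log units; beyond the scatter), and 4-nitrophenyl in place of 3-fluorophenyl gives an 11-fold lower number from compound 1 to compound 4 (1.04 log units; beyond the scatter). On the saturated chain carbon bound to an oxygen on an aromatic ring, then, the large gain seen with compound 3 does not depend on a pyridine ring, and what the ring carries can count for as much as the ring itself.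

Nothing measured here explains why two such different groups give numbers within the scatter of each other. As far as these compounds go, how far the gain belongs to the nitro group itself stays open, and 4-chlorophenyl, 4-cyanophenyl or 4-aminophenyl groups on the same chain carbon would bear on that.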